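A few compounds are considered here, and "the series" means these few. Any claim that something is new, unique, unknown or untested is made for them only; others in the source may bear on it.

Compound 1 `FC(F)(F)c1cc(Nc2nc3nonc3nc2Nc2cc(C(F)(F)F)cc(C(F)(F)F)c2)cc(C(F)(F)F)c1`: 6100 nM
Compound 2 `FC(F)(F)c1cccc(Nc2nc3nonc3nc2Nc2cccc(C(F)(F)F)c2)c1`: 700 nM
Compound 3 `Fc1cccc(Nc2nc3nonc3nc2Nc2ccccc2F)c1`: 190 nM

In an assay on mitochondria from L6 cells (Rattus norvegicus) for activation, with a stated time of 90 min (a lower number here means that less compound is needed, a higher number that more compound is needed for the effect), compound 3 has the lowest of the three numbers. Compound 2 gives 700 nM, a higher number, and the gap between compound 3 and compound 2 lies beyond the usual scatter. Compound 1 gives 6100 nM, the highest of the three, and its gap to compound 3 is wider still. No pair among these three differs in one place only, so none of the measured steps tracks a single change.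

Compound 4 `CCOc1ccc(Nc2nc3nonc3nc2Nc2ccccc2F)cc1` is the next compound, not yet measured in this assay. It differs from compound 3 in one place:
4-ethoxyphenyl in place of 3-fluorophenyl on a nitrogen on an aromatic ring
Among the measured compounds shown here, with no measured step of this kind to lean on, the expectation for compound 4 rests on compound 3 alone, and a modest move to a somewhat higher number is assumed, not large beyond the scatter. Compound 4 is expected to give 400 nM, within a range from 120 nM to 1400 nM. The expected step is a 2.1-fold higher number from compound 3 to compound 4 (0.32 log units; beyond the scatter).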

Compound 4, half-maximal effective concentration: 3800 nM
Beside the measured number, compound 4's estimate is 9.5-fold (0.98 log units) below it, outside the stated range (above it).
By their numbers in this assay, from the lowest: compound 3; then compound 2; then compounds 4 and 1 (each within the scatter of the next).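

In this assay, among the compounds shown here, putting 4-ethoxyphenyl in place of 3-fluorophenyl on a nitrogen on an aromatic ring gives a 20-fold higher number from compound 3 to compound 4 (1.30 log units; beyond the scatter), the first measured step here that follows a single change. It shows that the number is highly sensitive to the group at this place, with the rest of compound 3 unchanged. The entering group differs by its heavy atoms and by a hydrogen-bond acceptor, but nothing available bears on what drives the step.

For the compounds shown here, this exchange removes the fluorine, adds the ethoxy group and shifts the substituent from the 3- to the 4-position all at once, so the one step cannot say which of these matters. On these data alone, what a methoxy group, a hydroxyl group or an amine in place of the ethoxy group would give also stays open.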